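A bromine on the thiophene of an inactive compound

The source may report more compounds than this note shows. Statements on the series, on what has been measured and on what is new or still open speak of the compounds shown alone.

In a functional assay on A549 cells (Homo sapiens) for inhibition, read by sulforhodamine B assay, with a stated time of 74 h (a higher number here means a weaker inhibitor, a lower number a stronger inhibitor), compound 1 (`Cc1ccc(S(=O)(=O)N2C(=O)COC23C=CC(=O)C=C3)cc1`) gives 110 nM as a measured number. Compound 2 (`O=C1C=CC2(C=C1)OCC(=O)N2S(=O)(=O)c1ccccc1`) reads > 10000 nM which is a limit of the assay. Compound 3 (`O=C1C=CC2(C=C1)OCC(=O)N2S(=O)(=O)c1cccs1`) reads > 10000 nM which is likewise a limit. It thus stands at the limit of > 10000 nM in this assay, at which 2 of the 3 values shown sit, with no true number to start from. Compound 4 (`O=C1C=CC2(C=C1)OCC(=O)N2S(=O)(=O)c1ccc(Br)s1`) differs by bromo in place of hydrogen on an aromatic carbon as bromo in place of hydrogen on an aromatic carbon, turning thiophen-2-yl to 5-bromothiophen-2-yl. Two large steps bear on this: an at least 90-fold higher number from compound 1 to compound 2 (1.95 log units; beyond the scatter) and an at least 90-fold higher number from compound 1 to compound 3 (1.95 log units; beyond the scatter) each lose the 4-methylphenyl group of compound 1. Read in reverse, they suggest that a substituent may restore activity, so a large drop is expected, though compound 4 may also stay at the limit. The expected change is an at least 6.6-fold lower number from compound 3 to compound 4 (0.82 log units; beyond the scatter) toward a stronger inhibitor. For compound 4 the estimated value is 1500 nM with an expected range from 150 nM to 10000 nM in this estimate.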

Compound 4, half-maximal inhibitory concentration: 50 nM
The estimate for compound 4 lay 30-fold (1.48 log units) above the measured number; the measured number lies below the stated range.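

In this assay a single bromo on the thiophene, next to the ring sulfur, gives an at least 200-fold lower number from compound 3 to compound 4 (2.30 log units; beyond the scatter) and an at least 200-fold lower number from compound 2 to compound 4 (2.30 log units; beyond the scatter). Both steps start from a limit of the assay and so give only a bound: the limit of > 10000 nM in this assay, at which 2 of the 4 values shown sit. The 4-methylphenyl group of compound 1 is thus not the only sulfonyl substituent that gives a measured number here, and 5-bromothiophen-2-yl gives a 2.2-fold lower number from compound 1 to compound 4 (0.34 log units; beyond the scatter), a modest step. The compounds shown leave open whether this gain is specific to bromine, since no chloro, methyl or amine at this place on the thiophene is among them.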